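The source may report more compounds than this note shows. Statements on the series, on what has been measured and on what is new or still open speak of the compounds shown alone.

Measured so far in this test:
compound 1 `O=C(Nc1cccc(-n2cc(-c3ccncc3)c(-c3ccc(Cl)c(O)c3)n2)c1)Nc1cc(C(F)(F)F)cc(C(F)(F)F)c1`: > 50000 nM
compound 2 `COc1cc(-c2nn(-c3cccc(NC(=O)Nc4ccc(Cl)c(C(F)(F)F)c4)c3)cc2-c2ccncc2)ccc1Cl`: > 32500 nM

In a functional assay on MOLT-4 cells (Homo sapiens) for inhibition, read by sulforhodamine B assay, with a stated time of 48 h (on this read-out lower numbers stand for higher toxicity in this test and higher numbers for lower toxicity in this test), compound 1 gives > 50000 nM, which is a limit of the test rather than a number (the limit of > 50000 nM in this assay, at which 1 of the 2 values shown sits). Compound 2 gives > 32500 nM, also a limit (the limit of > 32500 nM in this assay, at which 1 of the 2 values shown sits). Going by the values given here, with both values only limits, no step between measured compounds can be taken. Compound 3 `O=C(Nc1cccc(-n2cc(-c3ccncc3)c(-c3ccc(Cl)c(O)c3)n2)c1)Nc1cccc(C(F)(F)F)c1` differs from compound 1 in one place: hydrogen in place of trifluoromethyl on an aromatic carbon. No step beyond the usual scatter is expected. The estimated value for compound 3 is 50000 nM, with a range from 20000 nM to 120000 nM. The expected step is therefore a number no higher from compound 1 to compound 3 (the limit leaves the size open), most likely again reported only as a limit.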

Compound 3, concentration lethal to 50% of the cells: > 32500 nM
Compound 3 was reported as a limit; the forecaster's own chance of this, stated with the estimate: 75%; the middle value lies beyond the limit too.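

Going by these compounds alone, compound 1 and compound 3 both gave only limits in this assay, so no step between them can be read. The compounds shown leave open whether hydrogen in place of trifluoromethyl changes toxicity in this test at all.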